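Swapping chloro for amino: what the data suggest

The source may report more compounds than this note shows. Statements on the series, on what has been measured and on what is new or still open speak of the compounds shown alone.

Of the compounds shown here, three have been tested in a functional assay on DU-145 cells (Homo sapiens) for cytotoxicity, read by sulforhodamine B assay, with a stated time of 48 h; a lower number here means that less compound is tolerated, a higher number that more compound is tolerated. Compound 1 `ClCc1ccccc1Cn1cnc2c(Cl)nc(Cl)nc21` gives 6310 nM. Compound 2 `ClCc1cccc(Cn2cnc3c(Cl)nc(Cl)nc32)c1` gives 5620 nM. The difference between the cores of compound 1 and compound 2 is not broken down here, and their two values lie within the usual scatter of each other. Compound 3 `Nc1nc(Cl)c2ncn(Cc3ccccc3CCl)c2n1` gives 70800 nM. Compound 3 arises from compound 1 by a single change, (amino in place of chloro on an aromatic carbon), and that change produced an 11-fold higher number from compound 1 to compound 3 (1.05 log units; beyond the scatter).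

Compound 4 `Nc1nc(Cl)c2ncn(Cc3cccc(CCl)c3)c2n1` has not yet been measured. It arises from compound 2 by the same change, (amino in place of chloro on an aromatic carbon), at a place described in exactly the same words as before. Because the same change gave an 11-fold higher number from compound 1 to compound 3 (1.05 log units; beyond the scatter), compound 4 is expected to show a step of about an 11-fold higher number from compound 2 to compound 4 (1.04 log units; beyond the scatter) in this assay. The estimate for compound 4 is therefore 62000 nM, with a range expected to run from 25000 nM to 150000 nM. This expectation rests on a single earlier example of the change, so the range is kept wide.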

Compound 4, concentration lethal to 50% of the cells: 40700 nM
The estimate for compound 4 lay 1.5-fold (0.18 log units) above the measured number; low and high end bracket the measured number.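

The swap of chloro for amino gave a 7.2-fold higher number from compound 2 to compound 4 (0.86 log units; beyond the scatter) in this assay, a step in the same direction as the one seen on the core of compound 1. Set side by side, the two steps cannot be told apart: the same change on two cores in this assay, an 11-fold higher number (1.05 log units; beyond the scatter) from compound 1 to compound 3 and a 7.2-fold higher number (0.86 log units; beyond the scatter) from compound 2 to compound 4, 1.5-fold (0.19 log units) apart, within the scatter of two such steps. This shows that the change carried over between these two cores in this one assay, but two pairs are too few to set a rule for the whole series, and the numbers alone do not explain why the step occurs.

On these data alone, it remains open whether another group in the same place, such as a methylamino group, a hydroxyl or a methoxy group, would shift the number as far as amino does. As far as these compounds go, it is also open whether the step would hold on a core that carries a longer chain in place of the chloromethyl group, or in other kinds of cells.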